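A few compounds are considered here, and "the series" means these few. Any claim that something is new, unique, unknown or untested is made for them only; others in the source may bear on it.

Measured so far:
- compound 1, `CCOc1cc(NC(=O)C2(NC(=O)c3ccc4c(C5CCCC5)c(-c5ncc(Cl)cn5)n(C)c4c3)CCC2)ccc1/C=C/C(=O)OCC(C)C`: > 5 h
- compound 2, `CCOc1cc(NC(=O)C2(NC(=O)c3ccc4c(C5CCCC5)c(-c5ncc(Cl)cn5)n(C)c4c3)CCC2)ccc1/C=C/C(=O)OCc1ccccc1`: > 5 h
- compound 3, `CCOc1cc(NC(=O)C2(NC(=O)c3ccc4c(C5CCCC5)c(-c5ncc(Cl)cn5)n(C)c4c3)CCC2)ccc1/C=C/C(=O)OCC(N)=O`: 0.983 h

In an ADME assay (liver) for pharmacokinetics, with Liver microsome (Homo sapiens) as the target, using microsomes (a higher number here means that the compound lasts longer, a lower number that the compound disappears faster), compound 1 gives only a limit of the assay, > 5 h. Compound 2 likewise gives only a limit, > 5 h. Compound 3 is the one compound with a real number, 0.983 h, so it stands at the bottom of what is shown. The step from compound 1 to compound 2 cannot be read because the limit of > 5 h in this assay, at which 2 of the 3 values shown sit, hides its size (a step that the two limits leave unreadable from compound 1 to compound 2). Two steps are readable: an at least 5.0-fold lower number from compound 1 to compound 3 (0.70 log units; beyond the scatter) and an at least 5.0-fold lower number from compound 2 to compound 3 (0.70 log units; beyond the scatter), each exchanging the whole group on the chain carbon of the ester for a carbamoyl.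

Compound 4, `CCCN(C)C(=O)COC(=O)/C=C/c1ccc(NC(=O)C2(NC(=O)c3ccc4c(C5CCCC5)c(-c5ncc(Cl)cn5)n(C)c4c3)CCC2)cc1OCC`, keeps that carbamoyl frame and alters only its nitrogen: methyl(propyl)amino in place of amino on a carbonyl carbon. Within the data shown here, no measured step exchanges groups on this carbonyl carbon, so the two readable steps bear on it only loosely; they show that this end of the molecule can move this assay strongly, but both moved toward compound 3, not away from it. A change staying within the carbamoyl is expected to be smaller than those. Compound 4 is therefore estimated at 1.5 h, with a range from 0.5 h to 4 h, meaning an expected step of a 1.5-fold higher number from compound 3 to compound 4 (0.18 log units; within the scatter), within or only just beyond the scatter.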

Compound 4, half-life: 0.317 h
Beside the measured number, compound 4's estimate is 4.7-fold (0.68 log units) above it; measured number outside the range, below it.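

Changing the carbamoyl itself, and not only replacing it as a whole, moves the number in this assay: methyl(propyl)amino in place of amino on a carbonyl carbon gives a 3.1-fold lower number from compound 3 to compound 4 (0.49 log units; beyond the scatter), a step beyond the scatter. This shows that the amino group of compound 3 is not a silent spot, and that the added carbons on this nitrogen go with a shorter half-life, not a recovery towards the esters with isopropyl or phenyl. Set against those two esters, the new carbamoyl gives an at least 15-fold lower number from compound 1 to compound 4 (1.19 log units; beyond the scatter) and an at least 15-fold lower number from compound 2 to compound 4 (1.19 log units; beyond the scatter), and the true size of both steps stays unread: the limit of > 5 h in this assay, at which 2 of the 4 values shown sit.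

The compounds shown do not separate the methyl from the propyl, and a carbamoyl carrying only methylamino, only propylamino or dimethylamino on that carbonyl carbon would be needed to tell which part goes with the drop. As far as these compounds go, it also remains open where a ring amine such as morpholine on that carbon, or a carboxylic acid in place of the whole carbamoyl, would fall in this range.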